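Swapping trifluoromethyl for phenyl on the shared core

The compounds below may be only part of what the source reports. "The series", "measured", "known", "first", "only" and "open" are said of these compounds alone.

Compound 1 `CC(=O)c1ccc(NC(=O)Cn2nc(-c3ccc(Cl)cc3)nc2N)cc1` gives 22%
Compound 2 `C/C(=N/O)c1ccc(NC(=O)Cn2nc(C(F)(F)F)nc2N)cc1` gives 3.53%

Within the data shown here, both readings come from a functional assay on SK-OV-3 cells (Homo sapiens) for inhibition, read by sulforhodamine B assay, with a stated time of 48 h, tested at 10 uM (on this read-out higher numbers stand for more inhibition of growth at the one concentration tested and lower numbers for less inhibition of growth), and are the only measurements available. Compound 2 stands lowest of the two at 3.53%, and the gap to compound 1 lies beyond the usual scatter. The two compounds differ in more than one place, so that gap cannot be assigned to any single change.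

Compound 3 `C/C(=N/O)c1ccc(NC(=O)Cn2nc(-c3ccccc3)nc2N)cc1` has phenyl in place of trifluoromethyl on an aromatic carbon of compound 2, a change counted as phenyl in place of trifluoromethyl on an aromatic carbon. Among the measured compounds shown here, no measured pair isolates this change, so its size can only be judged indirectly. For the measured compounds named here, the one guide is compound 1, which carries a substituted phenyl on that carbon and gives 22%, though it also differs from compound 3 elsewhere. A moderate rise in this assay is therefore expected, near the edge of the scatter. The expected change is a number 11.5 percentage points higher from compound 2 to compound 3 (beyond the scatter). For compound 3 the estimated value is 15%, with an expected range from 4% to 30%.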

Compound 3, percent growth inhibition at one concentration: 15.2%
Compound 3: the middle estimate sits 0.2 percentage points below what was measured, within the range that was stated.
By their numbers in this assay, from the lowest: compound 2; then compounds 3 and 1 (each within the scatter of the next).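

In this assay, the step from trifluoromethyl to phenyl on this aromatic carbon, with the rest of the structure unchanged, is a number 11.7 percentage points higher from compound 2 to compound 3 (beyond the scatter). Among these compounds, this is the first direct reading of a change at this position, the ring carbon between two ring nitrogen atoms, since the earlier two compounds differed in more than one place and their gap could not be assigned to any one of them. It shows that the group on this carbon alone can shift growth inhibition at the one concentration tested by more than the usual scatter, although the step rests on a single pair and is modest in size, and no measurement available here bears on why the phenyl group gives this result.

On these data alone, what an amine, a carboxylic acid or a longer alkyl chain on this aromatic carbon would do remains open, so a single step cannot show whether ring size, atom count or some other feature of the entering group matters. It is also open whether a chlorine on the phenyl ring changes the reading, as no pair shown isolates that change.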